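Adenosine A3 binding series: sulfanylmethyl substituent changes

The source may report more compounds than this note shows. Statements on the series, on what has been measured and on what is new or still open speak of the compounds shown alone.

Measured so far:
compound 1 `N#Cc1c(N)nc(SCC(=O)NCO)c(C#N)c1-c1ccc(OCC2CC2)cc1` gives 8%
compound 2 `N#Cc1c(N)nc(SCc2nnn[nH]2)c(C#N)c1-c1ccc(OCC2CC2)cc1` gives 1%

Both measured compounds show little displacement of the labelled ligand in an assay on CHO cells for displacement of a labelled ligand from adenosine receptor A3 (Homo sapiens), read by scintillation counting, with a stated time of 120 min, tested at 1 uM; a lower number here means less inhibition, a higher number more inhibition at the concentration tested (going by the name of the read-out). Compound 2 holds the lowest of the two numbers; its nearest neighbour is compound 1, and the step of a number 7 percentage points lower from compound 1 to compound 2 (within the scatter) lies within the scatter, so the two values cannot be ordered. The change at the saturated chain carbon bound to a sulfur, from (hydroxymethyl)carbamoyl to 1H-tetrazol-5-yl, therefore did not move the read-out beyond noise.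

Compound 3 `COC(=O)c1cccc(CSc2nc(N)c(C#N)c(-c3ccc(OCC4CC4)cc3)c2C#N)c1` is not yet measured in this assay. It differs from compound 2 as follows: 3-(methoxycarbonyl)phenyl in place of 1H-tetrazol-5-yl on a saturated chain carbon bound to a sulfur. Among the measured compounds shown here, the only measured step concerns a different exchange at the same place and was within the scatter, so no measured step bears directly on the entering 3-(methoxycarbonyl)phenyl group. For the measured compounds named here, with two low values as the sole reference and no step showing that this position can lift inhibition, compound 3 is expected to stay low, with the step of a number 14 percentage points higher from compound 2 to compound 3 (beyond the scatter) expected to fall within or near the scatter, more likely upward than downward given the larger group. For compound 3 the estimate is 15%, ranging from 0% to 45%.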

Compound 3, a percentage reported as inhibition, at one concentration (the size of the read-out at that concentration, not a potency): 4%
Beside the measured number, compound 3's estimate is 11 percentage points above it; the range from low to high includes it.
By their numbers in this assay, from the lowest: compounds 2, 3 and 1 (each within the scatter of the next).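

In this assay, 3-(methoxycarbonyl)phenyl in place of 1H-tetrazol-5-yl on a saturated chain carbon bound to a sulfur gives a number 3 percentage points higher from compound 2 to compound 3 (within the scatter), and the same group in place of (hydroxymethyl)carbamoyl gives a number 4 percentage points lower from compound 1 to compound 3 (within the scatter). The position has now carried three different groups, including a six-membered aromatic ring of carbon only, and neither the larger entering group nor the absence of the hydrogen-bond donor of 1H-tetrazol-5-yl separates compound 3 from compound 2 or compound 1 in this read-out. No measurement on hand accounts for how closely these three values lie together.

Still open, going by these compounds, is whether any group at this place can lift inhibition at the concentration tested, for instance a carboxylic acid in place of the methoxycarbonyl group, an amine on the phenyl ring, or a longer chain between the sulfur and that ring. Because all three compounds sit together at the low end of the read-out, the compounds shown also leave open whether changes elsewhere on the shared core would make this position's substituents distinguishable.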